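Swapping the amide aryl group on a P2X7 antagonist scaffold

The source may hold more compounds than are shown below. What is called first, only, known or untested is meant among the compounds shown, and "the series" means these compounds.

Measured compounds in an assay on HEK293 cells for antagonist activity at P2X purinoceptor 7 (Homo sapiens), read by fluorescence, with a stated time of 2 h; on this read-out lower numbers stand for stronger inhibition and higher numbers for weaker inhibition:
- compound 1, `O=C(NC1CC1)c1cccc(S(=O)(=O)Oc2ccc(-c3cncn3C3CCN(C(=O)c4ccc(Cl)c(C(F)(F)F)c4)CC3)cc2)c1`, gives 88 nM
- compound 2, `O=C(c1ccc(Oc2ccccc2)cc1)N1CCC(n2cncc2-c2ccc(OS(=O)(=O)c3cccc4cnccc34)cc2)CC1`, gives 187 nM
- compound 3, `CS(=O)(=O)c1ccc(C(=O)N2CCC(n3cncc3-c3ccc(OS(=O)(=O)c4cccc5cnccc45)cc3)CC2)cc1`, gives 25 nM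

Compound 3 stands lowest of the three in this assay, and both of its gaps to the others lie beyond the scatter. For the measured compounds named here, the one measured step that changes a single place is a 7.5-fold lower number from compound 2 to compound 3 (0.87 log units; beyond the scatter), which shows that the group carried on the carbonyl carbon can move the number a good deal.

Compound 4, `CN(C)c1cccc(C(=O)N2CCC(n3cncc3-c3ccc(OS(=O)(=O)c4cccc5cnccc45)cc3)CC2)c1`, is reached from compound 3 by a change in that same place: 3-(dimethylamino)phenyl in place of 4-(methylsulfonyl)phenyl on a carbonyl carbon. Going by the values given here, no measured pair covers this particular swap, so the only guidance is that the step from compound 2 to compound 3 was modest yet beyond the scatter when the group on the carbonyl carbon changed. On that basis a shift back toward a higher number is expected for compound 4, estimated as a 3.2-fold higher number from compound 3 to compound 4 (0.51 log units; beyond the scatter), and its value in this assay is estimated at 80 nM, with a range from 25 nM to 250 nM.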

Compound 4, half-maximal inhibitory concentration: 155 nM
Estimate against measurement, compound 4: 1.9-fold (0.29 log units) below; the range from low to high includes it.
By their numbers in this assay, from the lowest: compound 3; then compounds 1, 4 and 2 (each within the scatter of the next, the first and the last beyond it).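

Replacing 4-(methylsulfonyl)phenyl with 3-(dimethylamino)phenyl on the carbonyl carbon gives a 6.2-fold higher number from compound 3 to compound 4 (0.79 log units; beyond the scatter) in this assay, the second step at this position to lie beyond the scatter. Compound 2 and compound 4 lie within the scatter of each other despite their different groups, so among these three compounds, only the 4-(methylsulfonyl)phenyl group of compound 3 stands apart. Nothing measured here explains why this group differs from the other two.

This swap changes both the group and its place on the ring, so the compounds shown cannot separate those two changes. On these data alone, that question stays open until 3-(methylsulfonyl)phenyl or 4-(dimethylamino)phenyl is seen at this position on the same core.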